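Fluoro for Methyl: Expecting No Shift in Minimum Dose

This account rests on a few compounds, and the source may have more. Where it says the series, first, only, none or still open, it means among the compounds named here.

Compound 1, `COc1ccc(Cn2cc(CO/N=C/c3c(-c4ccccc4)nc4c(C)cccn34)nn2)cc1`, gives 40 mg/kg in a functional assay on the whole organism (strain NMRI) with Mus musculus as the target, with a stated time of 0.5 h; on this read-out higher numbers stand for an effect only at larger amounts of compound and lower numbers for an effect already at smaller amounts.
Compound 2, `COc1ccc(Cn2cc(CO/N=C/c3c(-c4ccc(C)cc4)nc4c(C)cccn34)nn2)cc1`, gives 40 mg/kg in this assay.
Compound 3, `Cc1ccc(-c2nc3c(C)cccn3c2/C=N/O)cc1`, gives 20 mg/kg in this assay.

Compound 2 stands level with compound 1 at the digits shown, the two together the highest numbers of the three; compound 3 differs from compound 2 only within the scatter. Going by the values given here, the one step available, no change at the digits printed from compound 1 to compound 2 (within the scatter), shows that a small change on the outer phenyl ring left the number unchanged. Compound 4, `COc1ccc(Cn2cc(CO/N=C/c3c(-c4ccc(F)cc4)nc4c(C)cccn34)nn2)cc1`, differs from compound 2 by fluoro in place of methyl on an aromatic carbon. Since that earlier step was flat, the step from compound 2 to compound 4 is expected to stay within the scatter, no change at the digits printed from compound 2 to compound 4 (within the scatter). Compound 4 is therefore estimated at 40 mg/kg, between 20 mg/kg and 80 mg/kg.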

Compound 4, minimum effective dose: 40 mg/kg
Compound 4: the middle estimate sits on the measured number at the digits printed; the range from low to high includes it.
By their numbers in this assay, from the lowest: compounds 3, 1, 2 and 4 (each within the scatter of the next).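

In this assay, the change from 4-methylphenyl to 4-fluorophenyl reads no change at the digits printed from compound 2 to compound 4 (within the scatter), and fluoro in place of hydrogen reads no change at the digits printed from compound 1 to compound 4 (within the scatter). This place on the outer phenyl ring, para to a large group, therefore carries hydrogen, methyl or fluoro at the same printed dose, so the flat result now extends to an atom other than carbon. No measurement here offers an explanation for this flatness.

As far as these compounds go, whether an amine, a carboxylic acid or a longer chain at this same place would also leave the dose level remains open.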